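Nitro for Methyl on a Shared Core: Expected Growth Inhibition

This account rests on a few compounds, and the source may have more. Where it says the series, first, only, none or still open, it means among the compounds named here.

Measured compounds:
- compound 1, `Cc1ccc(-c2ccc([N+](=O)[O-])cc2)n1-c1ccc(-c2nc3ccc(F)cc3s2)cc1`: 1670 nM
- compound 2, `COc1ccc2nc(-c3ccc(-n4c(C)ccc4-c4ccc(C)cc4)cc3)sc2c1`: 4010 nM

Both compounds were tested in a functional assay on MDA-MB-231 cells (Homo sapiens) for cytotoxicity, read by sulforhodamine B assay, with a stated time of 48 h; a higher number here means a weaker inhibitor of growth, a lower number a stronger inhibitor of growth. Compound 1 gives 1670 nM in this assay. Compound 2 gives 4010 nM in this assay, the higher of the two numbers, with compound 1 giving a lower number by a margin beyond the scatter. The two compounds differ in more than one place, so no single structural change accounts for that gap.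

Compound 3, `COc1ccc2nc(-c3ccc(-n4c(C)ccc4-c4ccc([N+](=O)[O-])cc4)cc3)sc2c1`, has not yet been measured. It differs from compound 2 in one place: nitro in place of methyl on an aromatic carbon. Compound 3 thus carries the nitro group already present in compound 1 while keeping the rest of compound 2 unchanged.

For the measured compounds named here, no measured pair shows this change alone. Since compound 1, which also carries the nitro group, gives 1670 nM, compound 3 is expected to give a somewhat lower number than compound 2, and the step of a 1.6-fold lower number from compound 2 to compound 3 (0.21 log units; within the scatter) is expected to be modest. Compound 3 is estimated at 2500 nM, within a range from 1000 nM to 6000 nM.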

Compound 3, concentration for 50% growth inhibition: 4560 nM
Beside the measured number, compound 3's estimate is 1.8-fold (0.26 log units) below it; the range from low to high includes it.
By their numbers in this assay, from the lowest: compound 1; then compounds 2 and 3 (each within the scatter of the next).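

In this assay the change from 4-methylphenyl to 4-nitrophenyl can now be read on its own, and it gives a 1.1-fold higher number from compound 2 to compound 3 (0.06 log units; within the scatter) on the shared core, so on a core carrying methoxy, methyl and nitro cannot be told apart at this position in this measurement. With the nitro group held in place, the change of methoxy in place of fluoro on an aromatic carbon gives a 2.7-fold higher number from compound 1 to compound 3 (0.44 log units; beyond the scatter) and is the only single change shown here that clears the usual spread of repeated measurements. Nothing available here gives a reason for either step.

The compounds shown leave open whether an amine, a carboxylic acid or a longer chain such as butyl at this same place on the six-membered ring would also match methyl and nitro, or would shift the number clearly. They also leave open whether methyl and nitro would still match on the fluoro-bearing core of compound 1, since one pair on one core cannot show how general this result is.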